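Aniline swap on the shared core: compound 3 to compound 4

The compounds below may be only part of what the source reports. "The series", "measured", "known", "first", "only" and "open" are said of these compounds alone.

The series shares one core, seen in compound 1 `COc1ccc(Nc2cc(Nc3ccc(Oc4ccncc4-c4cccnc4)c(F)c3)ncn2)cc1` and compound 2 `Fc1cc(Nc2cc(Nc3ccc(Cl)cc3)ncn2)ccc1Oc1ccncc1-c1cccnc1`, each carrying a different aryl group on the nitrogen on the aromatic ring. In a functional assay on MDA-MB-231 cells (Homo sapiens) for cytotoxicity, read by MTT assay, with a stated time of 72 h (a higher number here means a weaker inhibitor, a lower number a stronger inhibitor), compound 1 gives "not determined" (no result reported) and compound 2 gives "not determined" (no result reported). Compound 3 `Fc1cc(Nc2cc(Nc3cccc(Cl)c3)ncn2)ccc1Oc1ccncc1-c1cccnc1` is the only member with a number: in this assay compound 3 gives 90 nM, so it stands alone among the entries shown, and no ranking within the series is possible from these data.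

Compound 4 `Fc1ccc(Nc2cc(Nc3ccc(Oc4ccncc4-c4cccnc4)c(F)c3)ncn2)cc1` is not yet measured. Relative to compound 3 the change is 4-fluorophenyl in place of 3-chlorophenyl on a nitrogen on an aromatic ring. Among the compounds with values here, no measured pair shows this change, so its size is not known from these data. The expectation is a small step toward a weaker inhibitor in this assay, estimated at a 1.7-fold higher number from compound 3 to compound 4 (0.22 log units; within the scatter), a step that may well fall inside the usual scatter of repeated measurements. On that basis compound 4 is expected to give about 150 nM in this assay, with a range of 50 nM to 500 nM.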

Compound 4, half-maximal inhibitory concentration: 14100 nM
Compound 4: middle estimate off by 94-fold (1.97 log units), on the low side; measured number outside the range, above it.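

In this assay, within the data shown here, the aryl group on the nitrogen on an aromatic ring proves to be a position where a single swap can matter: 4-fluorophenyl in place of 3-chlorophenyl gives a 160-fold higher number from compound 3 to compound 4 (2.19 log units; beyond the scatter), the only readable step so far. The leaving and entering groups have the same heavy-atom count and the same single six-membered aromatic ring of carbon only, so the step arises without any change in those counts; the swap changes both the halogen and the name's position number, and this one pair cannot divide the step between those two differences. Nothing measured here bears on the origin of the step.

The steps involving compound 1 and compound 2 cannot be read, so the shown data give no ranking of the 4-methoxyphenyl or 4-chlorophenyl groups against this pair. Still open, going by these compounds, is whether 3-fluorophenyl would stay close to compound 3 or fall toward compound 4, which would separate the identity of the halogen from its placement, and how a phenyl carrying an amine or a carboxylic acid would read at this position.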